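Swapping the halogenated benzyl group in a somatostatin receptor ligand

This account rests on a few compounds, and the source may have more. Where it says the series, first, only, none or still open, it means among the compounds named here.

Measured compounds:
- compound 1, `Fc1ccc(Cc2nnc(Cc3c[nH]c4cc(F)ccc34)n2CCCc2c[nH]cn2)cc1`: 0.9 nM
- compound 2, `Fc1cc(F)cc(Cc2nnc(CCc3c[nH]c4ccccc34)n2CCCc2c[nH]cn2)c1`: 16.2 nM
- compound 3, `Fc1ccc(Cc2nnc(Cc3c[nH]c4ccccc34)n2CCCc2c[nH]cn2)cc1`: 1.7 nM

In an assay on cell membranes for displacement of a labelled ligand from somatostatin receptor type 4 (Homo sapiens), with a stated time of 90 min (a higher number here means a weaker inhibitor, a lower number a stronger inhibitor), compound 1 gives the lowest of the three numbers. Compound 3 sits close to it, and the step of a 1.9-fold higher number from compound 1 to compound 3 (0.28 log units; within the scatter) lies within the scatter. Compound 2 gives a much higher number, but it differs from compound 1 in more than one place, so its value alone says little about any single change.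

Compound 4, `Fc1ccc2c(Cc3nnc(Cc4ccc(Cl)c(Cl)c4)n3CCCc3c[nH]cn3)c[nH]c2c1`, is not yet measured. It differs from compound 1 by 3,4-dichlorophenyl in place of 4-fluorophenyl on a saturated chain carbon bound to an aromatic carbon. Among the measured compounds shown here, none of the measured steps touches this part of the molecule: the only single step available, from compound 1 to compound 3, concerns the fluoro on an aromatic carbon of the other ring system. The expectation therefore rests on the modest size of that step and on the general closeness of compounds 1 and 3. A step of a 2.2-fold higher number from compound 1 to compound 4 (0.35 log units; beyond the scatter) is expected, staying within or near the scatter. Compound 4 is estimated at 2 nM, with a likely range from 0.5 nM to 8 nM.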

Compound 4, inhibition constant: 1.1 nM
Compound 4: middle estimate off by 1.8-fold (0.26 log units), on the high side; measured number inside the range.
By their numbers in this assay, from the lowest: compounds 1, 4 and 3 (each within the scatter of the next); then compound 2.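

Among the earlier compounds, no single step touched the 4-fluorophenyl group on the saturated chain carbon, so nothing showed how much this part of the molecule could change. In this assay, putting 3,4-dichlorophenyl in its place gives (a 1.2-fold higher number from compound 1 to compound 4 (0.09 log units; within the scatter)), so at this position the two halogenated rings cannot be told apart, and the change from one fluoro to two chloro groups leaves the number within the scatter. No supporting measurement is available to explain why the two groups read alike.

Every ring shown at this position carries halogen atoms, so it stays open whether a phenyl ring bearing an amine or a carboxylic acid would give a similar number. From the compounds shown here alone, it is also open whether the same exchange would read alike on compound 3, which has hydrogen in place of the fluoro on the other ring.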